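From 4-cyanophenyl to 3-cyanophenyl in a small series

A few compounds are considered here, and "the series" means these few. Any claim that something is new, unique, unknown or untested is made for them only; others in the source may bear on it.

Readings so far from a functional assay on B16-F10 cells (Mus musculus) for inhibition, read by MTT assay, with a stated time of 72 h (a higher number here means a weaker inhibitor, a lower number a stronger inhibitor), are as follows
- compound 1 `CC1(C)CC(NC(=O)Nc2cccc(Cl)c2)c2cc(Br)ccc2O1` gives "not determined" (no result reported)
- compound 2 `CC1(C)CC(NC(=S)Nc2cccc(C#N)c2)c2cc(Br)ccc2O1` gives 7000 nM
- compound 3 `CC1(C)CC(NC(=S)Nc2ccc(C#N)cc2)c2cc(F)ccc2O1` gives 5000 nM

Among the compounds with values here, compound 3 sits within the usual scatter of compound 2, its only numerical neighbour, and compound 1 offers no number for comparison. Compound 4 `CC1(C)CC(NC(=S)Nc2cccc(C#N)c2)c2cc(F)ccc2O1` has 3-cyanophenyl in place of 4-cyanophenyl on an amide-type nitrogen, counted as 3-cyanophenyl in place of 4-cyanophenyl on an amide-type nitrogen in the comparison of the two structures. Within the data shown here, no measured pair shows this change alone, so no step beyond the scatter is expected in this assay for now. The estimated 1.2-fold higher number from compound 3 to compound 4 (0.08 log units; within the scatter) reflects that expectation. For compound 4 the expected value is 6000 nM within an estimated range from 2500 nM to 15000 nM as a half-maximal inhibitory concentration.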

Compound 4, half-maximal inhibitory concentration: 35000 nM
Compound 4: the middle estimate sits 5.8-fold (0.77 log units) below what was measured; measured number above the stated range.
By their numbers in this assay, from the lowest: compounds 3 and 2 (each within the scatter of the next); then compound 4.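

In this assay, 3-cyanophenyl in place of 4-cyanophenyl on an amide-type nitrogen weakens inhibition (a 7.0-fold higher number from compound 3 to compound 4 (0.85 log units; beyond the scatter)), so the two cyanophenyl isomers are not interchangeable when fluoro is present. With 3-cyanophenyl kept, fluoro in place of bromo on an aromatic carbon also weakens inhibition (a 5.0-fold higher number from compound 2 to compound 4 (0.70 log units; beyond the scatter)), so the halogen matters in this subset. No supporting data explain either step.

As far as these compounds go, whether 4-cyanophenyl keeps its advantage when bromo is present remains open. So does the effect of an amine or a carboxylic acid in place of the nitrile.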